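The source may report more compounds than this note shows. Statements on the series, on what has been measured and on what is new or still open speak of the compounds shown alone.

Measured so far: compound 1 `COc1ccc(CNC(=O)/C=C/c2coc3cc(OC)ccc3c2=O)cc1` gives 15700 nM in a functional assay (QGY7701 cells, Homo sapiens) for inhibition, read by MTT assay, with a stated time of 48 h; a lower number here means a stronger inhibitor, a higher number a weaker inhibitor; compound 2 `COc1ccc(CNC(=O)/C=C/c2coc3cc(O)ccc3c2=O)cc1` gives 10000 nM; compound 3 `O=C(/C=C/c1coc2cc(O)ccc2c1=O)Nc1ccccc1` gives 17900 nM.

Compound 1 stands second highest of the three numbers, nearest to compound 3 and furthest from compound 2, all within the scatter. Compound 4 `COc1ccc2c(=O)c(/C=C/C(=O)Nc3cccc(C)c3)coc2c1` differs from compound 1 by 3-methylphenyl in place of 4-methoxybenzyl on an amide-type nitrogen. Within the data shown here, no measured step covers this change: the only step, a 1.6-fold lower number from compound 1 to compound 2 (0.20 log units; within the scatter), concerns the oxygen on the aromatic ring, not the amide nitrogen. Compound 2 and compound 3, which differ at the amide nitrogen, show numbers within the scatter of each other. A step of no size beyond the scatter is therefore expected, a 1.1-fold higher number from compound 1 to compound 4 (0.06 log units; within the scatter). Compound 4 is estimated at 18000 nM, within 7000 nM to 45000 nM.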

Compound 4, half-maximal inhibitory concentration: > 100000 nM
Compound 4 ended at the assay's limit; the forecaster's own chance of this, stated with the estimate: 10%; middle value at least 5.5-fold (0.74 log units) away from the limit.
By their numbers in this assay, from the lowest: compounds 2, 1 and 3 (each within the scatter of the next). At a limit, above all of these: compound 4.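

In this assay, the amide-type nitrogen proves sensitive to its substituent: 3-methylphenyl in place of 4-methoxybenzyl gives an at least 6.3-fold higher number from compound 1 to compound 4 (0.80 log units; beyond the scatter). Among these compounds, this is the only step beyond the scatter, whereas a 1.6-fold lower number from compound 1 to compound 2 (0.20 log units; within the scatter) concerns the oxygen on the aromatic ring. The value of compound 4 is a limit of the assay, not a number: the limit of > 100000 nM in this assay, at which 1 of the 4 values shown sits.

Open, going by these compounds, is whether the step follows from benzyl versus phenyl or from methoxy versus methyl. Also open, on these data alone, is how an amine, a carboxylic acid or a longer chain on that nitrogen would read.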